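Swapping 3-Methoxyphenyl for 2-(4-Chlorophenyl)ethenyl on an Inactive Series

A few compounds are considered here, and "the series" means these few. Any claim that something is new, unique, unknown or untested is made for them only; others in the source may bear on it.

Three amides built on one shared core have been tested in a functional assay on HCT-116 cells (Homo sapiens) for antiproliferative activity, read by MTT assay, with a stated time of 48 h; a lower number here means a stronger inhibitor, a higher number a weaker inhibitor. Compound 1 `O=C(Nc1cc(Sc2ncn[nH]2)c(O)c2ccccc12)c1ccc([N+](=O)[O-])cc1` reaches only a limit of the assay, > 100000 nM. Compound 2 `COc1ccc(C(=O)Nc2cc(Sc3ncn[nH]3)c(O)c3ccccc23)cc1` likewise returns only a limit, > 100000 nM. Compound 3 `COc1cccc(C(=O)Nc2cc(Sc3ncn[nH]3)c(O)c3ccccc23)c1` also returns only a limit, > 100000 nM. None of the three steps can be read, because every value sits at the limit of > 100000 nM in this assay, at which 3 of the 3 values shown sit: the step that the two limits leave unreadable from compound 1 to compound 2 is unreadable, as are a step that the two limits leave unreadable from compound 1 to compound 3 and a step that the two limits leave unreadable from compound 2 to compound 3. Compound 3 therefore stands nowhere in particular; it is simply one of three compounds that all show no measurable inhibition within the range of this assay.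

Compound 4 `O=C(/C=C/c1ccc(Cl)cc1)Nc1cc(Sc2ncn[nH]2)c(O)c2ccccc12` carries a different group on the carbonyl carbon: 2-(4-chlorophenyl)ethenyl in place of 3-methoxyphenyl on a carbonyl carbon. Among the compounds with values here, no measured step bears directly on this change, since the exchanges so far concern methoxy, nitro and the position of methoxy on the aromatic carbon, and all were unreadable. Within the data shown here, with nothing among the measured compounds pointing towards measurable activity, compound 4 is expected to behave much like its three relatives; any step an at least 1.1-fold lower number from compound 3 to compound 4 (0.04 log units; that floor lies within the scatter) is expected to stay unreadable or small. The estimate for compound 4 in this assay is 90000 nM, with a plausible range from 20000 nM to 300000 nM.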

Compound 4, half-maximal inhibitory concentration: > 100000 nM
Compound 4: a limit, no number; the forecaster's own chance of this, stated with the estimate: 60%; middle value at least 1.1-fold (0.04 log units) from the limit.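

In this assay compound 4 gives > 100000 nM, which is a limit and not a number. None of the steps linking compound 4 to compound 1, compound 2 or compound 3 can be read, because all four values rest at the same limit: the limit of > 100000 nM in this assay, at which 4 of the 4 values shown sit.

The compounds shown leave open whether any group on the carbonyl carbon of the shared core can give a measurable value.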